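A few compounds are considered here, and "the series" means these few. Any claim that something is new, unique, unknown or untested is made for them only; others in the source may bear on it.

In a functional assay on 143B cells (Homo sapiens) for inhibition, read by MTT assay, with a stated time of 72 h (on this read-out higher numbers stand for weaker inhibition and lower numbers for stronger inhibition), the three measured compounds gave:

compound 1, `O=C(O)CCC(=O)OCCCCCCSc1ccc([N+](=O)[O-])c2nonc12`: 2830 nM
compound 2, `O=C(CCC(=O)OCCCCCCSc1ccc([N+](=O)[O-])c2nonc12)Nc1ccccc1`: 3850 nM
compound 3, `COc1ccccc1NC(=O)CCC(=O)OCCCCCCSc1ccc([N+](=O)[O-])c2nonc12`: 2120 nM

Compound 2 carries the highest number of the three, yet both a 1.4-fold higher number from compound 1 to compound 2 (0.13 log units; within the scatter) and a 1.8-fold lower number from compound 2 to compound 3 (0.26 log units; within the scatter) lie within the scatter, so the three sit together. Compound 4, `COc1ccc(NC(=O)CCC(=O)OCCCCCCSc2ccc([N+](=O)[O-])c3nonc23)cc1`, differs from compound 2 as follows: methoxy in place of hydrogen on an aromatic carbon. Among the compounds with values here, the one measured step of the same kind, a methoxy added to the anilino ring, is a 1.8-fold lower number from compound 2 to compound 3 (0.26 log units; within the scatter), which stays within the scatter, though there the group sits in the (2-methoxyphenyl)amino position rather than the (4-methoxyphenyl)amino position. On that basis no step beyond the scatter is expected, a 1.3-fold lower number from compound 2 to compound 4 (0.11 log units; within the scatter). Compound 4 is therefore estimated at 3000 nM, with a range from 1500 nM to 6000 nM.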

Compound 4, half-maximal inhibitory concentration: 3060 nM
The estimate for compound 4 lay 1.0-fold (0.01 log units) below the measured number; low and high end bracket the measured number.
By their numbers in this assay, from the lowest: compounds 3, 1, 4 and 2 (each within the scatter of the next).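

Moving the methoxy to the (4-methoxyphenyl)amino position, para to a large group, again leaves the number in this assay within the scatter (a 1.3-fold lower number from compound 2 to compound 4 (0.10 log units; within the scatter)). The two methoxy placings cannot be told apart (a 1.4-fold higher number from compound 3 to compound 4 (0.16 log units; within the scatter)), so this position shows no preference between them. Compound 4 also stays within the scatter of the carboxylic acid end of compound 1 (a 1.1-fold higher number from compound 1 to compound 4 (0.03 log units; within the scatter)).

From the compounds shown here alone, whether an amine or a nitrile on this ring would move the number beyond the scatter remains open. Nothing shown here gives a reason for these numbers.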